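A few compounds are considered here, and "the series" means these few. Any claim that something is new, unique, unknown or untested is made for them only; others in the source may bear on it.

Measured so far in an ADME assay on RD cells (Homo sapiens) for cytotoxicity, read by MTT assay, with a stated time of 24 h; on this read-out higher numbers stand for lower toxicity in this test and lower numbers for higher toxicity in this test:
- compound 1 `CCO/N=C/c1cc(C)c(OCCC(C)CCN2CCN(c3ccnc(N)c3)C2=O)c(C)c1`: 12900 nM
- compound 2 `CCc1nc(-c2ccc(OCCC(C)CCN3CCN(c4ccnc(N)c4)C3=O)cc2)no1`: > 100000 nM

Among the measured compounds shown here, compound 1 is the only compound here with a number in this assay; in this assay compound 1 gives 12900 nM. Compound 2 gives only a limit in this assay, > 100000 nM, meaning that no half-maximal toxic concentration was reached within the tested range. For the measured compounds named here, compound 1 therefore stands as the sole measured point, with the one further value being a limit rather than a number.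

Compound 3 `Cc1cc(-c2noc(C(F)(F)F)n2)cc(C)c1OCCC(C)CCN1CCN(c2ccnc(N)c2)C1=O` has not yet been tested. It differs from compound 1 at a single site: a group of 9 heavy atoms (3 carbon, 2 nitrogen, 1 oxygen, 3 fluorine; one five-membered aromatic ring with 3 hetero atoms) in place of a group of 5 heavy atoms (3 carbon, 1 nitrogen, 1 oxygen; no ring), on an aromatic carbon

Going by the values given here, no step between measured compounds is available to anchor this change. Still, the result for compound 2 is informative, since compound 2 also carries a five-membered aromatic ring with three hetero atoms on its aromatic ring and sits at the limit of > 100000 nM in this assay, at which 1 of the 2 values shown sits. Compound 3 is therefore expected to move toward lower toxicity, an expected step of a 2.3-fold higher number from compound 1 to compound 3 (0.37 log units; beyond the scatter). Compound 3 is estimated at 30000 nM in this assay, within a range from 10000 nM to 100000 nM.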

Compound 3, half-maximal cytotoxic concentration: > 100000 nM
Compound 3 gave a limit, no number (the forecaster's own chance of this, stated with the estimate: 35%); middle value at least 3.3-fold (0.52 log units) from the limit.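

In this assay, replacing the ring-free group of compound 1 with 5-(trifluoromethyl)-1,2,4-oxadiazol-3-yl, on the aromatic carbon para to a large group, gives an at least 7.7-fold higher number from compound 1 to compound 3 (0.88 log units; beyond the scatter). Compound 3 gives > 100000 nM, which is a limit and not a number, so the step has a lower bound but no known full size. Among the compounds shown here, this pair provides the first direct comparison at this position, showing that this single change on the shared core goes with lower toxicity in this test, and the values shown now gather at one limit: the limit of > 100000 nM in this assay, at which 2 of the 3 values shown sit.

The compounds shown do not separate the contribution of the five-membered ring from that of the trifluoromethyl group, a question that the same ring carrying a methyl group in place of trifluoromethyl could address. On these data alone, they also leave open how other groups at this position, such as a nitrile or a carboxylic acid, would compare, and how far toxicity in this test falls with compound 3 remains unknown.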